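A Heteroaryl Swap on a Shared Amide Core

The compounds below may be only part of what the source reports. "The series", "measured", "known", "first", "only" and "open" are said of these compounds alone.

Of the compounds shown here, two have numbers so far. Compound 1 `CCCCCCCCNC(=O)[C@@H](NC(=O)c1nccc2ccccc12)[C@@H](C)O` gives 88200 nM in a functional assay on HepG2 cells (Homo sapiens) for cytotoxicity, read by MTT assay, with a stated time of 48 h; a higher number here means a weaker inhibitor, a lower number a stronger inhibitor. Compound 2 `CCCCCCCCCCCCCCNC(=O)[C@@H](NC(=O)c1cc2ccccc2o1)[C@@H](C)O` gives 23400 nM in this assay, the lower of the two numbers and thus the stronger of the two, and its gap to compound 1 lies beyond the scatter. Compound 3 `CCCCCCCCCCCCCCNC(=O)[C@@H](NC(=O)c1nccc2ccccc12)[C@@H](C)O` has not been measured. Relative to compound 2 it carries isoquinolin-1-yl in place of 1-benzofuran-2-yl on a carbonyl carbon. Within the data shown here, no measured pair in this small set differs only by that swap, so there is no direct guide to how large such a step tends to be. Compound 1 also carries an isoquinolin-1-yl group, but it is not a one-change partner of compound 3, so its number can only show that this group sits in a compound with a measurable value. The step from compound 2 to compound 3 is expected to be modest, a 1.4-fold higher number from compound 2 to compound 3 (0.14 log units; within the scatter), quite possibly none beyond the scatter, with a slight lean toward a higher number. Compound 3 is estimated at 32000 nM, within a range from 10000 nM to 95000 nM.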

Compound 3, half-maximal inhibitory concentration: 28600 nM
Beside the measured number, compound 3's estimate is 1.1-fold (0.05 log units) above it; the range from low to high includes it.
By their numbers in this assay, from the lowest: compounds 2 and 3 (each within the scatter of the next); then compound 1.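

In this assay, isoquinolin-1-yl in place of 1-benzofuran-2-yl on a carbonyl carbon, whose other neighbour is an amide-type nitrogen, gives a 1.2-fold higher number from compound 2 to compound 3 (0.09 log units; within the scatter), so with the tetradecyl chain in place, exchanging a five-membered hetero ring for a six-membered one produces no difference that can be told from the scatter. Among these compounds, compound 3 also provides the first one-change comparison of the chain: hexyl in place of hydrogen on a saturated chain carbon, eight bonds along the chain from an amide-type nitrogen, gives a 3.1-fold lower number from compound 1 to compound 3 (0.49 log units; beyond the scatter) and is the only one of these two steps that reads beyond the scatter. Nothing measured alongside these compounds accounts for either step.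

The compounds shown leave open how the number moves with other chains, such as a decyl or an octadecyl chain, and whether the hexyl step would be the same with 1-benzofuran-2-yl on the carbonyl carbon. They also leave open whether a plain phenyl group, or a ring carrying an amine, would stay within the scatter of compound 3 at that place.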